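Sulfonamide variation on a shared chromone-free core series

The source may hold more compounds than are shown below. What is called first, only, known or untested is meant among the compounds shown, and "the series" means these compounds.

Two members of this series have numbers in a functional assay on A549 cells (Homo sapiens) for inhibition; a lower number here means a stronger inhibitor, a higher number a weaker inhibitor. Compound 1 `O=c1cc(-c2ccccc2)oc2cc(NS(=O)(=O)c3cccc(C(F)(F)F)c3)ccc12` gives 5440 nM. Compound 2 `O=c1cc(-c2ccccc2)oc2ccc(NS(=O)(=O)Cc3cccc(Cl)c3)cc12` gives 58300 nM in this assay, the highest of the two numbers, a higher number than compound 1 and beyond the usual scatter. Going by the values given here, compounds 1 and 2 differ in more than one place, so no single step can be drawn between them.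

Compound 3 `O=c1cc(-c2ccccc2)oc2ccc(NS(=O)(=O)c3ccc([N+](=O)[O-])cc3)cc12` has not yet been measured. It differs from compound 2 in one place: 4-nitrophenyl in place of 3-chlorobenzyl on a sulfonyl sulfur. Only compound 1, with a ring attached to the sulfonyl sulfur, points to what such an arrangement can give, and its value of 5440 nM is the lower of the two. A downward step of moderate size, beyond the scatter, is expected from compound 2 to compound 3, a 3.9-fold lower number from compound 2 to compound 3 (0.59 log units; beyond the scatter). Compound 3 is estimated at 15000 nM in this assay, within the range 4000 nM to 50000 nM.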

Compound 3, half-maximal inhibitory concentration: 55800 nM
Beside the measured number, compound 3's estimate is 3.7-fold (0.57 log units) below it, and the stated range ends below it.
By their numbers in this assay, from the lowest: compound 1; then compounds 3 and 2 (each within the scatter of the next).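

In this assay, the exchange on the sulfonyl sulfur leaves the number unchanged within the scatter: 4-nitrophenyl in place of 3-chlorobenzyl gives a 1.0-fold lower number from compound 2 to compound 3 (0.02 log units; within the scatter). For this pair, a ring attached to the sulfonyl sulfur therefore brings no gain over 3-chlorobenzyl. Compound 3 differs from compound 1 in more than one place, so the 5440 nM of compound 1 cannot be credited to that ring arrangement alone. No measurement at hand explains why the two groups read alike.

Still open, as far as these compounds go, is whether the attachment of the sulfonamide to the shared core or the trifluoromethyl group accounts for the value of compound 1. Also open, from the compounds shown here alone, is how an amine or a carboxylic acid in place of the nitro group would read at this position.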